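Benzoyl in place of acetyl: expected cytotoxicity of compound 4

A few compounds are considered here, and "the series" means these few. Any claim that something is new, unique, unknown or untested is made for them only; others in the source may bear on it.

Compound 1 `CCSc1nnc(COc2ccccc2C2=NOC(c3ccc(Cl)cc3Cl)C2)n1NC(C)=O` is the reference of the series. For the measured compounds named here, in an ADME assay (MDM cells, Homo sapiens) for cytotoxicity, read by resazurin assay, with a stated time of 3 days (on this read-out lower numbers stand for stronger inhibition and higher numbers for weaker inhibition), compound 1 gives 9.7 ug/mL, the higher of the two numbers measured so far. Its nearest neighbour is compound 3 `CC(=O)Nn1c(S)nnc1COc1ccccc1C1=NOC(c2ccc(Cl)cc2Cl)C1`, which in this assay gives 1.3 ug/mL; that step, a 7.5-fold lower number from compound 1 to compound 3 (0.87 log units; beyond the scatter), is hydrogen in place of ethyl on a sulfur. Compound 2 `CC(=O)Nn1c(COc2ccccc2C2=NOC(c3ccc(Cl)cc3Cl)C2)nnc1Sc1ccccc1` has "not determined" (no result reported) in this assay. Compound 4 `CCSc1nnc(COc2ccccc2C2=NOC(c3ccc(Cl)cc3Cl)C2)n1NC(=O)c1ccccc1` differs from compound 1 by phenyl in place of methyl on a carbonyl carbon, acetamido to benzamido. Going by the values given here, no measured step touches the carbonyl; the only step seen lies on the sulfur. Lacking any bearing step, compound 4 is expected to remain near compound 1, with a 1.4-fold lower number from compound 1 to compound 4 (0.14 log units; within the scatter) not beyond the scatter. The estimate for compound 4 is 7 ug/mL, within 2.5 ug/mL to 20 ug/mL.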

Compound 4, half-maximal inhibitory concentration: 1.8 ug/mL
Beside the measured number, compound 4's estimate is 3.9-fold (0.59 log units) above it; the measured number lies below the stated range.
By their numbers in this assay, from the lowest: compounds 3 and 4 (each within the scatter of the next); then compound 1.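

In this assay the carbonyl end of the side chain proves to be a place where the number moves: phenyl in place of methyl on a carbonyl carbon gives a 5.4-fold lower number from compound 1 to compound 4 (0.73 log units; beyond the scatter) and so adds a second sensitive place to the sulfur substituent. Only one replacement at this carbonyl carbon is shown, so no trend can be drawn from it. No measured property bears on this step.

Open, going by these compounds, is whether a longer chain, an amine or a substituted phenyl on this carbonyl carbon would move the number in the same direction. Also open, on these data alone, is how benzamido behaves with hydrogen on the sulfur in place of ethyl.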